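The source may report more compounds than this note shows. Statements on the series, on what has been measured and on what is new or still open speak of the compounds shown alone.

Compound 1 `O=S(=O)(NN1C(=S)S/C(=C\c2ccc(Cl)c(Cl)c2)C1O)c1ccc(Cl)cc1` and compound 3 `O=C1/C(=C/c2ccc(Cl)c(Cl)c2)SC(=S)N1NS(=O)(=O)c1ccccc1` are built on cores that are not identical, and the difference between the two cores is not broken down here. Within the data shown here, compound 2 `O=C1/C(=C/c2ccc(Cl)c(F)c2)SC(=S)N1NS(=O)(=O)c1ccccc1` is the partner of compound 3 in the one measured change. In a functional assay on HFF cells (Homo sapiens) for cytotoxicity (on this read-out lower numbers stand for stronger inhibition and higher numbers for weaker inhibition), compound 3 gives > 100000 nM, which is a limit of the assay rather than a number. In this assay compound 2 gives > 100000 nM, again a limit. Compound 1 gives > 100000 nM in this assay, also a limit. The change from compound 3 to compound 2 is fluoro in place of chloro on an aromatic carbon, and its step, a step that the two limits leave unreadable from compound 3 to compound 2, cannot be sized because the limit of > 100000 nM in this assay, at which 3 of the 3 values shown sit, covers both of its ends.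

Compound 4 `O=S(=O)(NN1C(=S)S/C(=C\c2ccc(Cl)c(Cl)c2)C1O)c1ccc(F)cc1` differs from compound 1 by fluoro in place of chloro on an aromatic carbon. Among the measured compounds shown here, this is the same kind of change as the one from compound 3 to compound 2, but not the same: there the place was ortho to a chloro group and meta to a large group, whereas here it is para to a large group. Given that compound 1 sits at > 100000 nM, the step from compound 1 to compound 4 is expected to be a step that the limit leaves unreadable from compound 1 to compound 4, with the measurement most likely again reported only as a limit. Compound 4 is therefore estimated at 150000 nM in this assay, with a range from 100000 nM to 400000 nM.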

Compound 4, half-maximal inhibitory concentration: > 100000 nM
Compound 4: no number, only a limit; the forecaster's own chance of this, stated with the estimate: 90%; the middle value is on the limit's open side.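

Compound 4 gives > 100000 nM in this assay, which is a limit of the assay and not a number. The change from compound 1 to compound 4 therefore cannot be sized, because both compounds rest on the same limit: the limit of > 100000 nM in this assay, at which 4 of the 4 values shown sit. The compounds shown leave open what actual values they would give and whether swapping chloro for fluoro alters the read-out at all.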